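Methylating a phenol on two related amide and urea scaffolds

A few compounds are considered here, and "the series" means these few. Any claim that something is new, unique, unknown or untested is made for them only; others in the source may bear on it.

Measured in a functional assay on ACHN cells (Homo sapiens) for inhibition, read by sulforhodamine B assay, with a stated time of 48 h, tested at 10 uM; a lower number here means a stronger effect, a higher number a weaker effect of the compound at the concentration tested:
Compound 1 `O=C(Nc1cccc(-n2cc(-c3ccncc3)c(-c3cc(O)cc(Cl)c3)n2)c1)Nc1ccc(Cl)c(Cl)c1` gives 6.85%.
Compound 2 `COc1cc(Cl)cc(-c2nn(-c3cccc(NC(=O)Nc4ccc(Cl)c(Cl)c4)c3)cc2-c2ccncc2)c1` gives 9.65%.
Compound 3 `O=C(Nc1cccc(-n2cc(-c3ccncc3)c(-c3cc(O)cc(Cl)c3)n2)c1)c1cc(C(F)(F)F)cc(C(F)(F)F)c1` gives 37.7%.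

Compound 1 and compound 2 share a core and differ only by methyl in place of hydrogen on an oxygen on an aromatic ring. That change made a step of a number 2.8 percentage points higher from compound 1 to compound 2 (within the scatter), so the two compounds read alike in this assay. Compound 3 carries a different core; how the core of compound 3 differs from that of compound 1 is not broken down here, and the two values simply show compound 3 well above compound 1 and compound 2.

Compound 4 `COc1cc(Cl)cc(-c2nn(-c3cccc(NC(=O)c4cc(C(F)(F)F)cc(C(F)(F)F)c4)c3)cc2-c2ccncc2)c1` is the unmeasured partner of compound 3: it differs from compound 3 by methyl in place of hydrogen on an oxygen on an aromatic ring, the same change, at the same place, as that from compound 1 to compound 2. Since that earlier change gave a step of a number 2.8 percentage points higher from compound 1 to compound 2 (within the scatter), compound 4 is expected to stay close to compound 3, with an expected step of a number 2.3 percentage points higher from compound 3 to compound 4 (within the scatter). Compound 4 is therefore estimated at 40%, likely between 26% and 56%.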

Compound 4, a percentage reported as activity, at one concentration (the size of the read-out at that concentration, not a potency): 58.2%
Estimate against measurement, compound 4: 18.2 percentage points below; measured number above the stated range.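

In this assay, going from hydroxy to methoxy on the amide-bearing compounds gave a number 20.5 percentage points higher from compound 3 to compound 4 (beyond the scatter), so here the methyl group came with a weaker effect at the concentration tested. For the compounds shown here, the change therefore did not carry over with the same size from one core to the other: the same change on two cores in this assay, a number 2.8 percentage points higher (within the scatter) from compound 1 to compound 2 and a number 20.5 percentage points higher (beyond the scatter) from compound 3 to compound 4, 17.7 percentage points apart, beyond the scatter of two such steps This rests on only two matched pairs, read at a single concentration, so it shows that the size of the step differed between these two cores, but it does not show why, nor how the change would read on any further core.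

The compounds shown leave open how a larger group on the same oxygen, such as an ethyl or a longer chain, would read on either core. They also leave open whether an amine in place of the hydroxy would give steps as far apart as those seen with methyl.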